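This account rests on a few compounds, and the source may have more. Where it says the series, first, only, none or still open, it means among the compounds named here.

Three compounds have been measured in an ADME assay on J774 cells (Mus musculus) for cytotoxicity, read by MTT assay, with a stated time of 48 h, tested at 150 ug/mL; a lower number here means a stronger effect, a higher number a weaker effect of the compound at the concentration tested:

compound 1, `O=C(N/N=C/c1ccccc1O)c1cnccn1`, giving 0%
compound 2, `O=C(N/N=C/c1cccc(O)c1)c1cnccn1`, giving 88%
compound 3, `N#Cc1ccccc1/C=N/NC(=O)c1cnccn1`, giving 70%

Compound 1 and compound 2 are built from the same atoms joined differently; the difference between the two cores is not broken down here. Compound 2 has the highest of the three numbers, and both other compounds lie beyond the scatter from it.

One structural change appears twice among these compounds. From compound 1 to compound 3 it is cyano in place of hydroxy on an aromatic carbon, and this change brought a number 70 percentage points higher from compound 1 to compound 3 (beyond the scatter). The compound not yet measured, compound 4, `N#Cc1cccc(/C=N/NC(=O)c2cnccn2)c1`, arises from compound 2 by cyano in place of hydroxy on an aromatic carbon. This is the same kind of change, not the same one: in compound 1 the group leaving sits ortho to a large group, while in compound 2 it sits meta to a large group.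

For compound 4 a much smaller step than the earlier one is expected, a number 2 percentage points higher from compound 2 to compound 4 (within the scatter), because compound 2 already gives 88% in this assay and the read-out is a percentage that cannot rise far beyond that. Compound 4 is therefore expected to give about 90% in this assay, with a range from 72% to 100%. Whether the change lands as it did before remains to be seen once compound 4 has been measured.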

Compound 4, a percentage reported as activity, at one concentration (the size of the read-out at that concentration, not a potency): 100%
For compound 4 the middle estimate is 10 percentage points below the measured one; the range from low to high includes it.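

In this assay, cyano in place of hydroxy on the core of compound 2 brought a number 12 percentage points higher from compound 2 to compound 4 (beyond the scatter), so the change moved the number in the same direction on both cores. The direction carried over from one core to the other, but the size of the step did not: the same change on two cores in this assay, a number 70 percentage points higher (beyond the scatter) from compound 1 to compound 3 and a number 12 percentage points higher (beyond the scatter) from compound 2 to compound 4, 58 percentage points apart, beyond the scatter of two such steps

These two pairs show that a step measured on one core cannot simply be reused as a size for another core in this series, yet they do not show what sets the size, as the two cores differ in where the leaving hydroxy sits and also start from very different numbers, and two pairs cannot separate these.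

The compounds shown leave open whether a different group on the same aromatic carbon, such as an amine or a carboxylic acid, would keep the number as high as in compound 4, which gives 100%. Equally open, going by these compounds, is whether such a group would bring the number down to that of compound 1, which gives 0%. They also leave open how these compounds behave at other concentrations, as each number here comes from a single tested concentration and is not a potency.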